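Shortening the thioether substituent on a shared aminodicyanopyridine core

A few compounds are considered here, and "the series" means these few. Any claim that something is new, unique, unknown or untested is made for them only; others in the source may bear on it.

Three compounds on a common core have been examined in an assay on CHO cells for displacement of a labelled ligand from adenosine receptor A3 (Homo sapiens), read by scintillation counting, with a stated time of 120 min, tested at 1 uM; on this read-out higher numbers stand for more inhibition at the one concentration tested (going by the name of the read-out) and lower numbers for less inhibition. Compound 1 `N#Cc1c(N)nc(SCc2cccc(C(N)=O)c2)c(C#N)c1-c1ccc(OCC2CC2)cc1` carries a 3-carbamoylbenzyl group on its sulfur and, in this assay, compound 1 gives 1%. Compound 2 `CCOc1ccc(-c2c(C#N)c(N)nc(SCC(N)=O)c2C#N)cc1` bears a much shorter carbamoylmethyl group on the sulfur together with an ethoxy group, and compound 2 reaches 20%. Compound 3 `C=CCOc1ccc(-c2c(C#N)c(N)nc(SCc3ccn[nH]3)c2C#N)cc1` combines an allyloxy group with a pyrazolylmethyl thioether and shows 13%. Compound 1 therefore stands lowest of the three, with compound 3 the nearer of the other two and compound 2 the further, both gaps beyond the usual scatter of such measurements.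

Compound 4 `N#Cc1c(N)nc(SCC(=O)NO)c(C#N)c1-c1ccc(OCC2CC2)cc1` keeps the cyclopropylmethoxy group of compound 1 but changes the thioether substituent: hydroxycarbamoyl in place of 3-carbamoylphenyl on a saturated chain carbon bound to a sulfur. Among the compounds with values here, no directly comparable pair among the measured compounds isolates this exact change, so the expectation rests on the resemblance of compound 4 to compound 2, whose short carbamoylmethyl thioether gave 20%. On this basis a modest upward step is expected, of a size near the edge of the scatter, namely a number 11 percentage points higher from compound 1 to compound 4 (beyond the scatter). Compound 4 is accordingly estimated to give 12% in this assay, within a range from 0% to 30%.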

Compound 4, a percentage reported as inhibition, at one concentration (the size of the read-out at that concentration, not a potency): 31%
For compound 4 the middle estimate is 19 percentage points below the measured one; measured number outside the range, above it.
By their numbers in this assay, from the lowest: compound 1; then compounds 3 and 2 (each within the scatter of the next); then compound 4.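

Within the data shown here, compounds 1 and 4 are the first pair here that differ in one place, as both keep the cyclopropylmethoxy group, so the effect of the thioether substituent can now be read on its own. In this assay, hydroxycarbamoyl in place of 3-carbamoylphenyl on a saturated chain carbon bound to a sulfur gives a number 30 percentage points higher from compound 1 to compound 4 (beyond the scatter), showing that at this position the six-membered aromatic ring can be lost without any loss of inhibition at the one concentration tested, and that the smaller group gives a reading beyond the scatter of the larger one. Nothing available accounts for this rise, so the step stands as an observation about these two structures alone.

From the compounds shown here alone, it remains open whether the rise depends on the hydroxycarbamoyl group itself, or whether a carboxylic acid, a methyl ester or a longer chain ending in the same group would read alike on the same core. Also unsettled is whether a single-concentration reading of this kind reflects a difference in potency, and whether the same change would carry over to compounds with an ethoxy or allyloxy group in place of cyclopropylmethoxy.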